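Dropping a Methoxy from an Inactive Sulfonamide

A few compounds are considered here, and "the series" means these few. Any claim that something is new, unique, unknown or untested is made for them only; others in the source may bear on it.

Compound 1 `COc1cccc(N2C(=O)COc3ccc(-c4cnc(Cl)c(NS(=O)(=O)c5ccc(F)cc5)c4)cc32)c1` is one of three close relatives tested in a functional assay on HeLa cells (Homo sapiens) for antiproliferative activity, read by MTT assay, with a stated time of 72 h; a higher number here means a weaker inhibitor, a lower number a stronger inhibitor. In this assay compound 1 gives only a limit, > 40000 nM. Compound 2 `COc1cccc(N2C(=O)COc3ccc(-c4cnc(OC)c(NS(=O)(=O)c5ccc(F)cc5)c4)cc32)c1` differs from compound 1 by methoxy in place of chloro on an aromatic carbon, and in this assay compound 2 likewise gives only a limit, > 40000 nM. Compound 3 `COc1ccc(N2C(=O)COc3ccc(-c4cnc5ccccc5c4)cc32)cc1`, built on a different core, also gives only a limit in this assay, > 40000 nM. Going by the values given here, the single step between measured neighbours, a step that the two limits leave unreadable from compound 1 to compound 2, has no readable size because of the limit of > 40000 nM in this assay, at which 3 of the 3 values shown sit.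

The not yet measured compound 4 `O=C1COc2ccc(-c3cnc(Cl)c(NS(=O)(=O)c4ccc(F)cc4)c3)cc2N1c1ccccc1` differs from compound 1 as follows: hydrogen in place of methoxy on an aromatic carbon. Among the compounds with values here, no measured step touches this particular change, so there is no basis for expecting a shift in this assay in either direction beyond the scatter. Compound 4 is therefore expected to remain near the limit, with an estimate of 60000 nM spanning 20000 nM to 200000 nM. The expected step, a step that the limit leaves unreadable from compound 1 to compound 4, is accordingly expected to be small.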

Compound 4, half-maximal inhibitory concentration: 10300 nM
Estimate against measurement, compound 4: 5.8-fold (0.77 log units) above, outside the stated range (below it).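

In this assay, going by these compounds alone, going from 3-methoxyphenyl to phenyl gives an at least 3.8-fold lower number from compound 1 to compound 4 (0.58 log units; beyond the scatter), the first step that can be read, and a lower number here means a stronger inhibitor. So the methoxy on this carbon ring matters: taking it away brings a compound with only a limit to a measured value, whereas the chloro-to-methoxy step between compound 1 and compound 2 cannot be read. The true size of the new step remains unknown because compound 1 gives only a limit: the limit of > 40000 nM in this assay, at which 3 of the 4 values shown sit.

As far as these compounds go, it remains open whether a small group such as a hydroxyl or an amine on this carbon would keep, extend or lose the gain seen with hydrogen. From the compounds shown here alone, it is also open whether the same removal from compound 2 would bring a similar shift.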